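The compounds below may be only part of what the source reports. "The series", "measured", "known", "first", "only" and "open" are said of these compounds alone.

Measured so far in a functional assay on HT-29 cells (Homo sapiens) for cytotoxicity, read by MTT assay, with a stated time of 24 h; a lower number here means a stronger inhibitor, a higher number a weaker inhibitor:
compound 1 `CN(C)CCN1CCN(CC(=O)Nc2ccc(-c3nc4cc(Cl)ccc4o3)cc2)CC1`, 4470 nM
compound 2 `CN(C)CCN1CCN(CC(=O)Nc2ccc(-c3nc4ccccc4o3)cc2)CC1`, 5310 nM
compound 3 `Cc1cc(-c2nc3cc(Cl)ccc3o2)ccc1NC(=O)CN1CCN(CCCN(C)C)CC1`, 9150 nM

Compounds 1 and 2 share one core; compound 3 is built on another, and the difference between the two cores is not broken down here. Compound 3 lies beyond the scatter only from compound 1; from compound 2 the gap is within it. Among the compounds with values here, the single measured one-point change is hydrogen in place of chloro on an aromatic carbon, giving a 1.2-fold higher number from compound 1 to compound 2 (0.07 log units; within the scatter). Compound 4 `Cc1cc(-c2nc3ccccc3o2)ccc1NC(=O)CN1CCN(CCCN(C)C)CC1` is not yet measured; it arises from compound 3 by the same change, (hydrogen in place of chloro on an aromatic carbon), at a place described in identical words. Compound 4 is expected to stay close to compound 3, with an estimated step of a 1.2-fold higher number from compound 3 to compound 4 (0.08 log units; within the scatter), because a 1.2-fold higher number from compound 1 to compound 2 (0.07 log units; within the scatter) lay within the scatter. The estimate for compound 4 in this assay is 11000 nM, expected between 5000 nM and 25000 nM.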

Compound 4, half-maximal inhibitory concentration: 15500 nM
Compound 4: middle estimate off by 1.4-fold (0.15 log units), on the low side; measured number inside the range.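

In this assay, hydrogen in place of chloro gives a 1.7-fold higher number from compound 3 to compound 4 (0.23 log units; within the scatter) on the core of compound 3, so the change carries to this second core without a step beyond the scatter. The two steps cannot be told apart: the same change on two cores in this assay, a 1.2-fold higher number (0.07 log units; within the scatter) from compound 1 to compound 2 and a 1.7-fold higher number (0.23 log units; within the scatter) from compound 3 to compound 4, 1.4-fold (0.15 log units) apart, within the scatter of two such steps. This shows that the change stays small on these two cores, but it does not show that chloro matters on either core, or that a further core would behave the same way.

Open, as far as these compounds go, is whether another group in place of the chloro, such as bromo, methoxy or a nitrile, would give a step beyond the scatter. Also open, from the compounds shown here alone, is how the difference between the two cores divides among its parts.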